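From Anilino to Bromo on the Shared Core

The source may hold more compounds than are shown below. What is called first, only, known or untested is meant among the compounds shown, and "the series" means these compounds.

Of the compounds shown here, three built on one shared core have been tested in a functional assay on the whole organism for inhibition, with Mus musculus as the target, at a dose of 10 mg/kg; a lower number here means less inhibition, a higher number more inhibition at the dose given (going by the name of the read-out). Compound 1 `CCCOCC1=CS(=O)(=O)c2ccccc2C1=O` gives 99.9%, and compound 2 `CCC(=O)OCC1=CS(=O)(=O)c2ccccc2C1=O` gives 99.5%, the step between them being a number 0.4 percentage points lower from compound 1 to compound 2 (within the scatter). Compound 3 `O=C1C(CNc2ccccc2)=CS(=O)(=O)c2ccccc21` gives 0%, the lowest of the three numbers, with compound 2 nearest and compound 1 furthest, both far above it and beyond the scatter.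

Compound 4 `O=C1C(CBr)=CS(=O)(=O)c2ccccc21` differs from compound 3 in one place: bromo in place of anilino on a saturated chain carbon bound to a double-bonded ring carbon. Going by the values given here, no measured step involves a bromo group, so the expectation rests on indirect evidence. Among the compounds with values here, the steps that bear on the change are a number 99.9 percentage points lower from compound 1 to compound 3 (beyond the scatter) and a number 99.5 percentage points lower from compound 2 to compound 3 (beyond the scatter), both large, showing that bringing anilino onto this carbon took inhibition from near-complete to none. Removing anilino again could recover inhibition, but bromo is neither propoxy nor propanoyloxy, so the size remains uncertain. An upward step of a number 70 percentage points higher from compound 3 to compound 4 (beyond the scatter) is expected. Compound 4 is estimated at 70%, with a range from 20% to 100%.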

Compound 4, a percentage reported as inhibition, in the whole organism at one dose (the size of the read-out at that dose, not a potency): 92.8%
The estimate for compound 4 lay 22.8 percentage points below the measured number; low and high end bracket the measured number.
By their numbers in this assay, from the lowest: compound 3; then compounds 4, 2 and 1 (each within the scatter of the next).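

In this assay, bromo in place of anilino gives a number 92.8 percentage points higher from compound 3 to compound 4 (beyond the scatter) and so shows that high inhibition at this saturated chain carbon does not need a chain linked through oxygen: a single bromine atom is enough. Set against the propanoyloxy and propoxy groups, the steps of a number 6.7 percentage points lower from compound 2 to compound 4 (within the scatter) and a number 7.1 percentage points lower from compound 1 to compound 4 (within the scatter) leave these three compounds indistinguishable at this dose, so among the four groups only anilino stands apart. Nothing available here explains this split between anilino and the other three groups.

Still open, from the compounds shown here alone, is whether the loss with anilino belongs to its nitrogen or to its aromatic ring, which a simple amine such as methylamino or a saturated ring such as piperidine on the same carbon could help separate. Going by these compounds, whether chloro or a longer ether chain would hold inhibition at this dose also remains unknown.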